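Cytotoxicity notes on a pyrazole amine series, Huh-7 cells

The source may hold more compounds than are shown below. What is called first, only, known or untested is meant among the compounds shown, and "the series" means these compounds.

Measured so far:
compound 1, `Cc1ccccc1-c1nn(-c2ccc(F)cc2F)cc1CNCCCCO` — > 20000 nM
compound 2, `CSc1ccc(-n2cc(CNCCN3CCN(C)CC3)c(-c3ccccc3C)n2)cc1` — 17000 nM
compound 3, `COC(=O)c1ccc(-c2nn(-c3ccc(F)cc3F)cc2CNCCN2CCN(C)CC2)cc1` — > 20000 nM

In an ADME assay on Huh-7 cells (Homo sapiens) for cytotoxicity (on this read-out lower numbers stand for higher toxicity in this test and higher numbers for lower toxicity in this test), compound 1 reaches only the assay limit of > 20000 nM. Compound 3 likewise gives only the limit of > 20000 nM in this assay. Going by the values given here, compound 2 is the one member of the set with a number in this assay, 17000 nM. Since neither other compound yields a number here, compound 2 stands as the single measured point against which anything further is read. Among the compounds with values here, no pair of compounds differs in one place only, so no step between measured compounds can be stated. The picture for the set is the limit of > 20000 nM in this assay, at which 2 of the 3 values shown sit.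

Compound 4, `Cc1ccc(-n2cc(CNCCN3CCN(C)CC3)c(-c3ccccc3C)n2)c(C)c1`, has not been measured in this assay. Against compound 2 the difference is 2,4-dimethylphenyl in place of 4-(methylsulfanyl)phenyl on an aromatic nitrogen. Within the data shown here, with no measured step to lean on, the expectation for compound 4 is that the change stays within the scatter, in no particular direction: compound 4 is estimated at 18000 nM in this assay, within 9000 nM to 36000 nM. That expected step, a 1.1-fold higher number from compound 2 to compound 4 (0.02 log units; within the scatter), is small, and a limit rather than a number would not be surprising for compound 4.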

Compound 4, half-maximal cytotoxic concentration: > 20000 nM
Compound 4 gave a limit, no number (the forecaster's own chance of this, stated with the estimate: 50%); at least 1.1-fold (0.04 log units) between middle value and limit.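

Going by these compounds alone, this is the first one-place comparison, and it falls on the aromatic nitrogen of the five-membered ring: in this assay, 2,4-dimethylphenyl in place of 4-(methylsulfanyl)phenyl gives an at least 1.1-fold higher number from compound 2 to compound 4 (0.07 log units; that floor lies within the scatter). Within the data shown here, the step is a floor and not a measured size, so it shows only that this exchange of a sulfur-bearing aryl group for an all-carbon one, at equal heavy-atom count, brings no lower number in this read-out, while the true distance between the two compounds could be small or large. Compound 2 also remains the only member of the set with a number, and the series as shown gathers at the top of the measurable range: the limit of > 20000 nM in this assay, at which 3 of the 4 values shown sit.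

How far compound 4 lies past the limit stays unknown, so the size of this change at this position cannot be read from the compounds shown. Also open, on these data alone, is how a 4-aminophenyl or a 4-carboxyphenyl on the same aromatic nitrogen would read, and whether any group there would give a number well inside the range of the assay.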